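Aryl methoxy shift on the enone chain: compound 2 to compound 3

A few compounds are considered here, and "the series" means these few. Any claim that something is new, unique, unknown or untested is made for them only; others in the source may bear on it.

Compound 1 `Cc1ccc(S/C(=C/c2ccc(C)s2)C(=O)c2ccc(Br)cc2)cc1`: > 100000 nM
Compound 2 `COc1ccc(/C=C(/Sc2ccc(C)cc2)C(=O)c2ccc(Br)cc2)cc1`: 50000 nM

Among the compounds with values here, in a functional assay on DU-145 cells (Homo sapiens) for inhibition, read by trypan blue exclusion, with a stated time of 96 h (on this read-out higher numbers stand for weaker inhibition of growth and lower numbers for stronger inhibition of growth), compound 2 gives 50000 nM, the only number in the set. Compound 1 returns only a limit of this assay, (the limit of > 100000 nM in this assay, at which 1 of the 2 values shown sits). Within the data shown here, the single measured step, an at least 2.0-fold lower number from compound 1 to compound 2 (0.30 log units; that floor lies within the scatter), exchanges one aryl ring for another and starts from that limit, so its true size is not fixed. Compound 3 `COc1ccccc1/C=C(/Sc1ccc(C)cc1)C(=O)c1ccc(Br)cc1` has the same atoms as compound 2, joined differently: 2-methoxyphenyl in place of 4-methoxyphenyl on a double-bonded chain carbon bound to a double-bonded chain carbon. Among the measured compounds shown here, no measured step moves a substituent within the same ring, so nothing in the data bears directly on this change; the step from compound 1 to compound 2 shows only that the ring on the double-bonded chain carbon can move the number. For compound 3 the expected step is no change at the digits printed from compound 2 to compound 3 (within the scatter), within the scatter. Compound 3 is estimated at 50000 nM, between 20000 nM and 100000 nM.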

Compound 3, concentration for 50% growth inhibition: 9000 nM
For compound 3 the middle estimate is 5.6-fold (0.74 log units) above the measured one; the measured number lies below the stated range.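

Moving the methoxy group on this ring is not a neutral change in this assay: with the atoms unchanged, 2-methoxyphenyl in place of 4-methoxyphenyl on the double-bonded chain carbon gives a 5.6-fold lower number from compound 2 to compound 3 (0.74 log units; beyond the scatter). The exchange of 5-methylthiophen-2-yl for 2-methoxyphenyl at this place gives an at least 11-fold lower number from compound 1 to compound 3 (1.04 log units; beyond the scatter), so this ring exchange now clears the scatter, which the floor of the earlier step did not. Compound 1 is a limit, so the step fixes only a floor: the limit of > 100000 nM in this assay, at which 1 of the 3 values shown sits.

Whether the lower number belongs to the methoxy group itself or to any group on that ring carbon stays open, since no compound shown carries, for example, an amine or a carboxylic acid there. On these data alone, whether the same shift holds with another ring in place of the 4-bromophenyl on the carbonyl also stays open.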